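The source may hold more compounds than are shown below. What is called first, only, known or untested is meant among the compounds shown, and "the series" means these compounds.

Measured in a functional assay on HeLa cells (Homo sapiens) for cytotoxicity, read by MTT assay, with a stated time of 72 h; a higher number here means a weaker inhibitor, a lower number a stronger inhibitor:
compound 1 `O=C(c1ccccc1)N(/N=N/c1ccc([N+](=O)[O-])cc1C(F)(F)F)c1ccc([N+](=O)[O-])cc1C(F)(F)F` gives 600 nM
compound 2 `O=C(c1ccccc1F)N(/N=N/c1ccc([N+](=O)[O-])cc1C(F)(F)F)c1ccc([N+](=O)[O-])cc1C(F)(F)F` gives 800 nM
compound 3 `O=C(c1ccc(F)cc1)N(/N=N/c1ccc([N+](=O)[O-])cc1C(F)(F)F)c1ccc([N+](=O)[O-])cc1C(F)(F)F` gives 1000 nM

Compound 3 has the highest number of the three, yet all three stand within the scatter of one another: a 1.7-fold higher number from compound 1 to compound 3 (0.22 log units; within the scatter) and a 1.3-fold higher number from compound 2 to compound 3 (0.10 log units; within the scatter). Compound 4 `CCOC(=O)CC(=O)N(/N=N/c1ccc([N+](=O)[O-])cc1C(F)(F)F)c1ccc([N+](=O)[O-])cc1C(F)(F)F` differs from compound 3 by (ethoxycarbonyl)methyl in place of 4-fluorophenyl on a carbonyl carbon. The measured steps covered only fluoro in place of hydrogen on an aromatic carbon, as in a 1.3-fold higher number from compound 1 to compound 2 (0.12 log units; within the scatter), and none moved the number beyond the scatter. Among the measured compounds shown here, no measured step exchanges the aromatic ring for an open ester chain, so nothing bears directly on this change; the expectation in this assay rests only on the small edits at this carbonyl having left the number within the scatter. Compound 4 is therefore expected to show a 1.5-fold higher number from compound 3 to compound 4 (0.18 log units; within the scatter), with wide uncertainty. Compound 4 is estimated at 1500 nM, in the range 500 nM to 6000 nM.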

Compound 4, half-maximal inhibitory concentration: 300 nM
Compound 4: middle estimate off by 5.0-fold (0.70 log units), on the high side, and the stated range ends above it.
By their numbers in this assay, from the lowest: compounds 4, 1, 2 and 3 (each within the scatter of the next, the first and the last beyond it).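

Unlike the fluoro edits, replacing the aromatic ring on this carbonyl carbon with the open (ethoxycarbonyl)methyl chain can move the number in this assay beyond the scatter (a 3.3-fold lower number from compound 3 to compound 4 (0.52 log units; beyond the scatter); a 2.7-fold lower number from compound 2 to compound 4 (0.43 log units; beyond the scatter)), although the change from the unsubstituted phenyl stays within it (a 2.0-fold lower number from compound 1 to compound 4 (0.30 log units; within the scatter)). The position therefore tolerates a chain with no ring, with no loss of strength in these comparisons. No evidence at hand explains these steps. Going by these compounds, whether the ester matters, or the chain alone, remains open. A carboxylic acid, an amine or a longer alkyl chain here could begin to separate the two.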